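A Larger Group on the Amide-type Nitrogen

This account rests on a few compounds, and the source may have more. Where it says the series, first, only, none or still open, it means among the compounds named here.

Measured so far:
compound 1 `COc1cc(NC(C)CCCNC(=O)Nc2ccc(Br)cc2)c2ncccc2c1`: 20000 nM
compound 2 `COc1cc(NC(C)CCCNC(=O)Nc2ccc(Cl)cc2)c2ncccc2c1`: 18000 nM

In a functional assay on HeLa cells (Homo sapiens) for inhibition, read by MTT assay, with a stated time of 72 h (on this read-out higher numbers stand for weaker inhibition and lower numbers for stronger inhibition), compound 1 gives the higher of these two numbers, yet the gap a 1.1-fold lower number from compound 1 to compound 2 (0.05 log units; within the scatter) lies within the scatter, so the two compounds cannot be told apart. Compound 3 `COc1cc(NC(C)CCCNC(=O)NNC(=O)Nc2cccc(Cl)c2)c2ncccc2c1` carries a different change: ((3-chlorophenyl)carbamoyl)amino in place of 4-bromophenyl on an amide-type nitrogen. Among the measured compounds shown here, the only measured step swaps one halogen for another and says nothing about this larger replacement, so no direction is expected beyond the scatter. The estimate for compound 3 is 20000 nM, between 6000 nM and 70000 nM, an expected step of no change at the digits printed from compound 1 to compound 3 (within the scatter).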

Compound 3, half-maximal inhibitory concentration: 44000 nM
Estimate against measurement, compound 3: 2.2-fold (0.34 log units) below; low and high end bracket the measured number.
By their numbers in this assay, from the lowest: compounds 2 and 1 (each within the scatter of the next); then compound 3.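

Among the compounds shown here, putting ((3-chlorophenyl)carbamoyl)amino on the amide-type nitrogen gives the first change here that lies beyond the scatter in this assay: a 2.2-fold higher number from compound 1 to compound 3 (0.34 log units; beyond the scatter), and a 2.4-fold higher number from compound 2 to compound 3 (0.39 log units; beyond the scatter). Both steps are modest and point towards weaker inhibition, so this position does respond to a larger replacement, unlike the halogen swap. Nothing measured here accounts for the shift.

As far as these compounds go, the larger group and the 3-chlorophenyl pattern arrive together, so their separate contributions remain open. From the compounds shown here alone, how an amine or a carboxylic acid on this nitrogen would read is also open.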